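Swapping the Pyridine Ring in a Weak Hydrazone

The compounds below may be only part of what the source reports. "The series", "measured", "known", "first", "only" and "open" are said of these compounds alone.

In a functional assay on EC9706 cells (Homo sapiens) for antiproliferative activity, read by MTT assay, with a stated time of 72 h (on this read-out lower numbers stand for stronger inhibition and higher numbers for weaker inhibition), three compounds have numbers so far
- compound 1 `C/C(=N\NC(=O)c1cccc(S(=O)(=O)N2CCOCC2)c1)c1ccccc1O` gives 1220 nM
- compound 2 `C/C(=N\NC(=O)c1cccc(S(=O)(=O)N2CCOCC2)c1)c1cc(O)ccc1O` gives 3510 nM
- compound 3 `O=C(N/N=C/c1ccccn1)c1cccc(S(=O)(=O)N2CCOCC2)c1` gives 44300 nM

Compound 3 has the highest number of the three, so it inhibits most weakly, and it lies beyond the scatter from both others. Compound 4 `O=C(N/N=C/c1cc(Br)ccc1O)c1cccc(S(=O)(=O)N2CCOCC2)c1` is still unmeasured. It differs from compound 3 in one place (5-bromo-2-hydroxyphenyl in place of pyridin-2-yl on a carbon with a double bond to nitrogen), with 5-bromo-2-hydroxyphenyl in place of pyridin-2-yl on a carbon with a double bond to nitrogen.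

Among the measured compounds shown here, no measured pair tests this swap directly. For the measured compounds named here, the one measured step, a 2.9-fold higher number from compound 1 to compound 2 (0.46 log units; beyond the scatter) for hydroxy in place of hydrogen on an aromatic carbon, is modest and involves no bromine. The better guide is looser: compound 1 (1220 nM) and compound 2 (3510 nM) also carry a hydroxy on a ring of carbon only, though they differ from compound 3 elsewhere too. A large drop in this assay is therefore expected, estimated as a 25-fold lower number from compound 3 to compound 4 (1.39 log units; beyond the scatter) and beyond the scatter. The estimate for compound 4 is 1800 nM with an expected range from 500 nM to 7000 nM in this read-out.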

Compound 4, half-maximal inhibitory concentration: 29700 nM
For compound 4 the middle estimate is 17-fold (1.22 log units) below the measured one; measured number above the stated range.
By their numbers in this assay, from the lowest: compound 1; then compound 2; then compounds 4 and 3 (each within the scatter of the next).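

In this assay, replacing the pyridin-2-yl on this carbon with 5-bromo-2-hydroxyphenyl gives a 1.5-fold lower number from compound 3 to compound 4 (0.17 log units; within the scatter), so the two compounds cannot be told apart. At this position, then, exchanging the ring nitrogen for a ring of carbon only that carries a hydroxy and a bromine does not by itself produce a measurable gain in inhibition. No measurement at hand offers an explanation for this result.

The compounds shown leave open what separates compound 1 and compound 2 from this pair, as neither differs from compound 3 or compound 4 in only one place. They also leave open whether an amine or a carboxylic acid on the phenyl ring, in place of the bromine, would shift the number.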